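The source may hold more compounds than are shown below. What is called first, only, known or untested is meant among the compounds shown, and "the series" means these compounds.

Measured so far:
compound 1, `C=C/C=C\[C@H](C)[C@H](OC(N)=O)[C@@H](C)[C@H](O)[C@@H](C)C/C(C)=C\[C@H](C)[C@@H](O)[C@@H](C)/C=C\CCc1ccc(Oc2ccccc2)cc1`: 4000 nM
compound 2, `C=C/C=C\[C@H](C)[C@H](OC(N)=O)[C@@H](C)[C@H](O)[C@@H](C)C/C(C)=C\[C@H](C)[C@@H](O)[C@@H](C)/C=C\CCc1cccc(F)c1`: 370 nM
compound 3, `C=C/C=C\[C@H](C)[C@H](OC(N)=O)[C@@H](C)[C@H](O)[C@@H](C)C/C(C)=C\[C@H](C)[C@@H](O)[C@@H](C)/C=C\CCc1cccc(O)c1C`: 490 nM

In a functional assay on MCF7 cells (Homo sapiens) for cytotoxicity (a lower number here means a stronger inhibitor, a higher number a weaker inhibitor), compound 3 stands second highest of the three numbers. Its nearest neighbour is compound 2, which gives 370 nM; the step of a 1.3-fold higher number from compound 2 to compound 3 (0.12 log units; within the scatter) lies within the scatter, so these two cannot be told apart. Compound 1 lies furthest away, giving 4000 nM, a gap that goes beyond the scatter.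

Compound 4 is `C=C/C=C\[C@H](C)[C@H](OC(N)=O)[C@@H](C)[C@H](O)[C@@H](C)C/C(C)=C\[C@H](C)[C@@H](O)[C@@H](C)/C=C\CCc1cccc(Cl)c1`. It differs from compound 3 in one place: 3-chlorophenyl in place of 3-hydroxy-2-methylphenyl on a saturated chain carbon, two bonds along the chain from a double-bonded chain carbon. Within the data shown here, the only measured step that touches this part of the molecule is a 1.3-fold higher number from compound 2 to compound 3 (0.12 log units; within the scatter), where a 3-fluorophenyl gave way to the 3-hydroxy-2-methylphenyl and the number hardly moved. Compound 4 carries a 3-chlorophenyl, a ring with a single halogen and no hydrogen-bond donor or acceptor, as in compound 2. The step is therefore expected to stay small and within the scatter: a 1.2-fold lower number from compound 3 to compound 4 (0.09 log units; within the scatter). For compound 4 in this assay the estimated value is 400 nM, with a range from 150 nM to 1100 nM.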

Compound 4, half-maximal inhibitory concentration: 400 nM
Compound 4: middle estimate and measured number agree at the digits printed, and the stated range covers the measured number.
By their numbers in this assay, from the lowest: compounds 2, 4 and 3 (each within the scatter of the next); then compound 1.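

In this assay, chloro in place of fluoro gives a 1.1-fold higher number from compound 2 to compound 4 (0.03 log units; within the scatter) and so leaves these two halogens indistinguishable on this ring. The change from the 3-hydroxy-2-methylphenyl to the 3-chlorophenyl gives a 1.2-fold lower number from compound 3 to compound 4 (0.09 log units; within the scatter) and thus adds a second small step: a ring with one hydrogen-bond donor and one acceptor cannot be told apart from a ring with neither. Nothing available here explains why these changes leave the number within the scatter.

Still open, on these data alone, is whether an amine or a carboxylic acid on this ring would shift the number beyond the scatter. As far as these compounds go, it is also open whether a longer chain in place of the 2-(3-chlorophenyl)ethyl, or a bromo in place of the chloro, would do so.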